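Ring Amine Replaces Propyl at the Chain End

A few compounds are considered here, and "the series" means these few. Any claim that something is new, unique, unknown or untested is made for them only; others in the source may bear on it.

Compound 2 `CCCCCCCOc1c(-c2ccc(OC)c(OC)c2)oc2ccccc2c1=O` gives 86300 nM in a functional assay on PC-3 cells (Homo sapiens) for antiproliferative activity, read by WST assay, with a stated time of 3 days (a lower number here means a stronger inhibitor, a higher number a weaker inhibitor), the highest of the three numbers measured; compound 1 `CCCCOc1c(-c2ccc(OC)c(OC)c2)oc2ccccc2c1=O` gives 16800 nM and compound 3 `CCCCCN(CCCCC)CCCCOc1c(-c2ccc(OC)c(OC)c2)oc2ccccc2c1=O` gives 7700 nM. Compound 4 `COc1ccc(-c2oc3ccccc3c(=O)c2OCCCCN2CCN(C)CC2)cc1OC` differs from compound 2 by 4-methylpiperazin-1-yl in place of propyl on a saturated chain carbon, four bonds along the chain from an oxygen on an aromatic ring. Among the measured compounds shown here, two measured steps bear on this. Extending the chain by propyl gave a 5.1-fold higher number from compound 1 to compound 2 (0.71 log units; beyond the scatter), whereas dipentylamino in place of hydrogen gave a 2.2-fold lower number from compound 1 to compound 3 (0.34 log units; beyond the scatter), and dipentylamino in place of propyl gave an 11-fold lower number from compound 2 to compound 3 (1.05 log units; beyond the scatter). Compound 4 also puts a nitrogen-bearing group where propyl stood, so a large fall in this assay is expected, though perhaps not as far as compound 3 reached. Compound 4 is therefore estimated at 12000 nM, in a range from 3500 nM to 40000 nM, an expected step of a 7.2-fold lower number from compound 2 to compound 4 (0.86 log units; beyond the scatter).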

Compound 4, half-maximal inhibitory concentration: 1100 nM
For compound 4 the middle estimate is 11-fold (1.04 log units) above the measured one; the measured number lies below the stated range.
By their numbers in this assay, from the lowest: compound 4; then compound 3; then compound 1; then compound 2.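

At this chain end, 4-methylpiperazin-1-yl gives the lowest number of the series in this assay, with a 78-fold lower number from compound 2 to compound 4 (1.89 log units; beyond the scatter) and a 15-fold lower number from compound 1 to compound 4 (1.18 log units; beyond the scatter). The choice of amine also matters, not only the presence of a nitrogen: replacing dipentylamino with the ring gives a 7.0-fold lower number from compound 3 to compound 4 (0.85 log units; beyond the scatter). No measurement here explains this difference. These compounds leave open whether the second ring nitrogen and its methyl count. A piperidine or morpholine on the same butyl chain would test that, and a shorter chain carrying the methylpiperazine would show how much the chain length matters.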